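The source may hold more compounds than are shown below. What is called first, only, known or untested is meant among the compounds shown, and "the series" means these compounds.

Measured compounds
Compound 1, `COc1cc2c(Nc3ccc(Cl)cc3F)ncnc2c(OC)c1OC`: > 30000 nM in a functional assay on SGC-7901 cells (Homo sapiens) for antiproliferative activity, read by MTT assay, with a stated time of 72 h; on this read-out higher numbers stand for weaker inhibition and lower numbers for stronger inhibition
Compound 2, `COc1cc2c(Nc3ccc(Br)c(F)c3)ncnc2c(OC)c1OC`: > 30000 nM
Compound 3, `COc1cc2c(Nc3cccc(I)c3)ncnc2c(OC)c1OC`: 8640 nM

Compound 3 is the only one of the three that gives a number in this assay at all; the values of compound 1 and compound 2 are each a limit of the assay, as noted in the limit of > 30000 nM in this assay, at which 2 of the 3 values shown sit. Compound 4, `COc1cc2c(Nc3cc(F)ccc3Br)ncnc2c(OC)c1OC`, has not yet been measured. It differs from compound 3 in that (2-bromo-5-fluorophenyl in place of 3-iodophenyl on a nitrogen on an aromatic ring).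

Among the measured compounds shown here, two measured steps bear on this change. The step of an at least 3.4-fold lower number from compound 1 to compound 3 (0.54 log units; beyond the scatter) and the step of an at least 3.4-fold lower number from compound 2 to compound 3 (0.54 log units; beyond the scatter) both run from a dihalophenyl group carrying a fluorine to the 3-iodophenyl group, and both are at least modest. The step that the two limits leave unreadable from compound 1 to compound 2 between the two dihalophenyl compounds cannot be read, since both sit at the limit. Going from compound 3 to compound 4 reverses the direction of those two readable steps: the 3-iodophenyl group leaves and a dihalophenyl group carrying fluorine enters. Compound 4 is therefore expected to give a higher number than compound 3, by a step of about a 2.9-fold higher number from compound 3 to compound 4 (0.46 log units; beyond the scatter), and quite possibly only a limit. The estimate for compound 4 in this assay is 25000 nM, with a range from 8000 nM to 60000 nM.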

Compound 4, half-maximal inhibitory concentration: 18400 nM
Estimate against measurement, compound 4: 1.4-fold (0.13 log units) above, and the stated range covers the measured number.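

In this assay, the change from 3-iodophenyl to 2-bromo-5-fluorophenyl on a nitrogen on an aromatic ring can now be read directly as a 2.1-fold higher number from compound 3 to compound 4 (0.33 log units; beyond the scatter), which shows that a dihalophenyl group carrying fluorine at this place need not end at the limit of the assay. Against the other two dihalophenyl groups only floors are available, an at least 1.6-fold lower number from compound 2 to compound 4 (0.21 log units; that floor lies within the scatter) and an at least 1.6-fold lower number from compound 1 to compound 4 (0.21 log units; that floor lies within the scatter), and as each floor lies within the scatter, these steps establish no order among the three compounds. Compound 1 and compound 2 each still give a limit and not a number, so the step between them cannot be read: the limit of > 30000 nM in this assay, at which 2 of the 4 values shown sit.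

The compounds shown carry only halogens on this phenyl group, which leaves open how an amine, a carboxylic acid or a plain phenyl group would compare with compound 3 at this place. Compound 3 and compound 4 also differ in both the identity and the number of their halogens, so it remains open which of these differences accounts for the step between them.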